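Oxazolyl ketone series: replacing the carbamoylpyridinyl group by chloro

This account rests on a few compounds, and the source may have more. Where it says the series, first, only, none or still open, it means among the compounds named here.

Measured compounds in an assay (Rattus norvegicus) for inhibition of Fatty-acid amide hydrolase 1 (Homo sapiens); on this read-out lower numbers stand for stronger inhibition and higher numbers for weaker inhibition:
compound 1 `O=C(CCCCCCc1ccccc1)c1ncc(-c2cccc(O)c2)o1`: 50 nM
compound 2 `Cc1cccnc1-c1cnc(C(=O)CCCCCCc2ccccc2)o1`: 15 nM
compound 3 `NC(=O)c1cccc(-c2cnc(C(=O)CCCCCCc3ccccc3)o2)n1`: 1 nM

Compound 3 gives the lowest number of the three. Going by the values given here, its steps to both neighbours lie beyond the scatter: a 15-fold lower number from compound 2 to compound 3 (1.18 log units; beyond the scatter) and a 50-fold lower number from compound 1 to compound 3 (1.70 log units; beyond the scatter), so compound 3 is the most potent compound measured so far. The smaller change a 3.3-fold lower number from compound 1 to compound 2 (0.52 log units; beyond the scatter) also lies beyond the scatter.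

Compound 4 `O=C(CCCCCCc1ccccc1)c1ncc(Cl)o1` is not yet measured. Its difference from compound 3 is chloro in place of 6-carbamoylpyridin-2-yl on an aromatic carbon.

All three measured steps exchange one aromatic group for another aromatic group at this place on the shared core; none removes the aromatic group altogether or puts a single atom there. The two steps that lead into compound 3 are the ones that bear on it most: the 6-carbamoylpyridin-2-yl gave the large steps of a 15-fold lower number from compound 2 to compound 3 (1.18 log units; beyond the scatter) and a 50-fold lower number from compound 1 to compound 3 (1.70 log units; beyond the scatter) when it replaced a 3-methylpyridin-2-yl or a 3-hydroxyphenyl. Taking it away for chloro is therefore expected to move the number upward in this assay, by a step at least as large as those, though no measured step directly covers a change of this kind, so the range is wide. For compound 4 the expected step is a 300-fold higher number from compound 3 to compound 4 (2.48 log units; beyond the scatter). Compound 4 is estimated at 300 nM, within 30 nM to 3000 nM.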

Compound 4, inhibition constant: 5 nM
For compound 4 the middle estimate is 60-fold (1.78 log units) above the measured one; the measured number lies below the stated range.
By their numbers in this assay, from the lowest: compound 3; then compound 4; then compound 2; then compound 1.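

In this assay, a large aromatic group at this position proves unnecessary for a low number: chloro, a single atom on the aromatic carbon next to the ring oxygen, gives a 3.0-fold lower number from compound 2 to compound 4 (0.48 log units; beyond the scatter) and a 10-fold lower number from compound 1 to compound 4 (1.00 log units; beyond the scatter) when it replaces the 3-methylpyridin-2-yl and the 3-hydroxyphenyl. Going by these compounds alone, the 6-carbamoylpyridin-2-yl still holds an advantage, with a 5.0-fold higher number from compound 3 to compound 4 (0.70 log units; beyond the scatter) on its removal, but this is only a modest step for the loss of 9 heavy atoms, a six-membered aromatic ring, and the group's hydrogen-bond donor and acceptors, so among the groups compared only this aromatic group gives a lower number than chloro, while those of compound 1 and compound 2 give higher ones. The compounds shown offer no evidence that explains this order.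

From the compounds shown here alone, it remains open whether the low number belongs to chloro in particular or extends to other small groups at this place, such as fluoro, bromo, methyl or nitrile. Going by these compounds, it is also open how much of the advantage of compound 3 rests on its carbamoyl group, which a carboxylic acid or a methyl ester on the same pyridine ring would test.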